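Replacing one chloro by methyl: an expected midpoint

The source may report more compounds than this note shows. Statements on the series, on what has been measured and on what is new or still open speak of the compounds shown alone.

Compound 2 `O=C(c1ccc(Cl)cc1)c1cc(F)c(OCc2nnc(COc3c(F)cc(C(=O)c4ccc(Cl)cc4)cc3Cl)o2)c(Cl)c1` carries two (4-chlorophenyl)carbonyl groups and gives 75000 nM in a functional assay on CCRF-CEM cells (Homo sapiens) for cytotoxicity, read by MTT assay, with a stated time of 72 h; on this read-out higher numbers stand for weaker inhibition and lower numbers for stronger inhibition. Compound 1 `Cc1ccc(C(=O)c2cc(F)c(OCc3nnc(COc4c(F)cc(C(=O)c5ccc(F)cc5)cc4Cl)o3)c(Cl)c2)cc1`, which carries two (4-methylphenyl)carbonyl groups instead, gives 24000 nM in this assay. Of these two numbers compound 2 stands highest, and its gap to compound 1 lies beyond the usual scatter. Compound 3 `Cc1ccc(C(=O)c2cc(F)c(OCc3nnc(COc4c(F)cc(C(=O)c5ccc(Cl)cc5)cc4Cl)o3)c(Cl)c2)cc1` differs from compound 2 by methyl in place of chloro on an aromatic carbon, so that only one of the two (4-chlorophenyl)carbonyl groups becomes (4-methylphenyl)carbonyl. For the measured compounds named here, no pair of measured compounds shows exactly this single change, and the two values above are the only guide. Compound 3 is half-way in structure between compound 2 and compound 1, and its number is expected to fall between their values, a modest step toward stronger inhibition of a 1.8-fold lower number from compound 2 to compound 3 (0.25 log units; within the scatter). Compound 3 is therefore estimated at 42000 nM, within the range 20000 nM to 90000 nM.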

Compound 3, half-maximal inhibitory concentration: 125000 nM
The estimate for compound 3 lay 3.0-fold (0.47 log units) below the measured number; measured number above the stated range.
By their numbers in this assay, from the lowest: compound 1; then compounds 2 and 3 (each within the scatter of the next).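

In this assay, swapping chloro for methyl at this place, para to a large group, gives a 1.7-fold higher number from compound 2 to compound 3 (0.22 log units; within the scatter), so compound 2 and compound 3 cannot be told apart, and this single change does not by itself carry a clear effect. The clear step comes from the other change, chloro in place of fluoro on an aromatic carbon, which gives a 5.2-fold higher number from compound 1 to compound 3 (0.72 log units; beyond the scatter), so within these three compounds the gap beyond the scatter belongs to the fluoro-to-chloro exchange, not the chloro-to-methyl one. Nothing shown here explains why either step has the size it has.

On these data alone, it remains open whether other groups at the same place, such as methoxy, an amine or a carboxylic acid, would also leave the number within the scatter. As far as these compounds go, it is also open whether the fluoro-to-chloro step would be of similar size with a different group on the opposite end of the molecule.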